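Thiophenyl for phenyl on the hydroxyphenyl pyridine core

A few compounds are considered here, and "the series" means these few. Any claim that something is new, unique, unknown or untested is made for them only; others in the source may bear on it.

Measured in an assay on isolated protein for inhibition of DNA topoisomerase 1 (Homo sapiens), with a stated time of 30 min, tested at 100 uM; on this read-out higher numbers stand for a stronger effect at the one concentration tested and lower numbers for a weaker effect:
compound 1, `Oc1ccc(-c2cc(-c3ccccc3)cc(-c3ccccc3)n2)cc1`: 52.9%
compound 2, `Oc1ccc(-c2cc(-c3ccccc3)cc(-c3cccs3)n2)cc1`: 4.9%
compound 3, `Oc1cccc(-c2cc(-c3ccccc3)nc(-c3ccccc3)c2)c1`: 11.5%

Compound 1 and compound 2 differ by thiophen-2-yl in place of phenyl on an aromatic carbon; the step is a number 48 percentage points lower from compound 1 to compound 2 (beyond the scatter). Compound 3 has the same atoms as compound 1, joined differently; the difference between the two cores is not broken down here. Compound 3 and compound 2 lie within the scatter of each other.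

Compound 4, `Oc1cccc(-c2cc(-c3ccccc3)nc(-c3cccs3)c2)c1`, is not yet measured. It differs from compound 3 by thiophen-2-yl in place of phenyl on an aromatic carbon, the same kind of change as from compound 1 to compound 2, but here the place is meta to a 3-hydroxyphenyl group rather than meta to a 4-hydroxyphenyl group. Within the data shown here, the one measured step of this kind is large and downward. A step of that full size cannot repeat, because compound 3 already stands at 11.5%. For compound 4 the expected step in this assay is a number 7.5 percentage points lower from compound 3 to compound 4 (within the scatter), which rests on that single earlier step. Compound 4 is estimated at 4%, between -5% and 14%.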

Compound 4, a percentage reported as inhibition, at one concentration (the size of the read-out at that concentration, not a potency): 9.1%
The estimate for compound 4 lay 5.1 percentage points below the measured number, and the stated range covers the measured number.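

In this assay, thiophen-2-yl in place of phenyl gives a number 2.4 percentage points lower from compound 3 to compound 4 (within the scatter), so the step does not carry over at the same size from one core to the other: the same change on two cores in this assay, a number 48 percentage points lower (beyond the scatter) from compound 1 to compound 2 and a number 2.4 percentage points lower (within the scatter) from compound 3 to compound 4, 45.6 percentage points apart, beyond the scatter of two such steps. The large drop on the core of compound 1 therefore cannot be treated as a fixed penalty for this change across the series. Among these compounds, compound 3 already stands at 11.5%, however, which leaves little room on this read-out for a downward step, so the pair does not show that the second core tolerates thiophen-2-yl, and readings at one concentration from only two pairs give neither potency nor a rule for further cores.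

As far as these compounds go, it remains open whether the drop on the core of compound 1 is specific to thiophen-2-yl or would also follow furan-2-yl or an aminomethyl-substituted phenyl in that place. Also open, from the compounds shown here alone, is how either core would respond to a methoxy group or a carboxylic acid in place of the hydroxyl.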